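Swapping the amide group of compound 2

The compounds below may be only part of what the source reports. "The series", "measured", "known", "first", "only" and "open" are said of these compounds alone.

Values so far in an in vivo functional assay on the whole organism for inhibition, with Rattus norvegicus as the target; a lower number here means that less compound is needed, a higher number that more compound is needed for the effect:

compound 1 `CCCc1nc(C)c(CC(=O)O)c(=O)n1Cc1ccc(-c2ccccc2-c2nnn[nH]2)cc1`: "not determined" (no result reported)
compound 2 `CCCCc1nc(C)c(CC(=O)N(C)C)c(=O)n1Cc1ccc(-c2ccccc2-c2nnn[nH]2)cc1`: 0.018 mg/kg

Going by the values given here, compound 2 holds the only number in this small set, so it cannot yet be ranked against anything. Compound 1 has no result to compare with it.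

The next compound to be tested is compound 3 `CCCCc1nc(C)c(CC(=O)N2CCC[C@H]2C(N)=O)c(=O)n1Cc1ccc(-c2ccccc2-c2nnn[nH]2)cc1`, which keeps the core of compound 2 and differs in one place. There, 2-carbamoylpyrrolidin-1-yl stands in place of dimethylamino on a carbonyl carbon (2-carbamoylpyrrolidin-1-yl in place of dimethylamino on a carbonyl carbon). Among the compounds with values here, no measured pair shows what a change of this kind does, so the expectation has only one anchor: compound 2 at 0.018 mg/kg in this assay. With the rest of the structure unchanged, a small move toward a higher dose seems most likely, though a result within the usual scatter would be no surprise.

The estimated move is a 1.7-fold higher number from compound 2 to compound 3 (0.22 log units; within the scatter) and it remains uncertain. The estimated value for compound 3 is 0.03 mg/kg, with an expected range from 0.008 mg/kg to 0.15 mg/kg in this measurement.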

Compound 3, dose for half-maximal effect: 0.023 mg/kg
Beside the measured number, compound 3's estimate is 1.3-fold (0.12 log units) above it; measured number inside the range.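

In this assay, the step is a 1.3-fold higher number from compound 2 to compound 3 (0.11 log units; within the scatter), even though the change replaces the small open-chain dimethylamino with 2-carbamoylpyrrolidin-1-yl, a group that brings a five-membered ring, a hydrogen-bond donor, a hydrogen-bond acceptor and a defined stereocentre. This first readable pair at the position shows that, on this carbonyl carbon, a much bulkier amine part can take the place of dimethylamino with no measurable difference in the dose needed in the whole animal. No measurement here explains why the two doses match, and a whole-animal dose alone cannot separate the possible reasons.

The compounds shown leave open how much each part of the new group contributes, such as whether a plain pyrrolidine ring without the carbamoyl group, a carboxylic acid in place of that carbamoyl group, or the opposite stereocentre would give a dose in the same range. A single step also cannot show how far this tolerance extends, for example to a six-membered piperidine ring or a longer chain on the amide nitrogen.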